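The source may report more compounds than this note shows. Statements on the series, on what has been measured and on what is new or still open speak of the compounds shown alone.

Compound 1, `Nc1nc(S)nc2ccc(Sc3ccc4ccccc4c3)cc12`: 5.52
Compound 2, `Nc1nc(N)c2c(S(=O)(=O)c3ccc4ccccc4c3)cccc2n1`: 4.82
Compound 3, `O=c1[nH]c(=S)c2cc(Sc3ccc4ccccc4c3)ccc2[nH]1`: 5.24

All three numbers come from an assay for inhibition of Dihydrofolate reductase (Homo sapiens); on this read-out lower numbers stand for lower potency and higher numbers for higher potency (the scale is a negative logarithm). Among them compound 2 stands lowest: compound 3 lies above it by a gap beyond the usual scatter, and compound 1 lies above it by a wider gap, also beyond the scatter. No two of these compounds differ in only one place, so no single measured step can be read off from them.

The unmeasured compound 4, `Nc1nc(O)c2c(S(=O)(=O)c3ccc4ccccc4c3)cccc2n1`, is reached from compound 2 by one change: hydroxy in place of amino on an aromatic carbon. Among the measured compounds shown here, no measured pair shows this change on its own. The only loose pointer is that compound 3, which carries oxygen where compound 1 carries nitrogen among several other differences, sits below compound 1 in this assay; that comparison involves more than one change and cannot be taken as a step.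

For compound 4 the expectation is a drop in this assay of moderate size, beyond the scatter, so that it would sit below compound 2. The expected step from compound 2 to compound 4 is a number 0.42 log units lower from compound 2 to compound 4 (beyond the scatter). Compound 4 is estimated at 4.4, with a range from 3.8 to 5.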

Compound 4, logarithm of the reciprocal of the active concentration, log(1/C): 4.85
Estimate against measurement, compound 4: 0.45 log units below; measured number inside the range.
By their numbers in this assay, from the lowest: compounds 2 and 4 (each within the scatter of the next); then compounds 3 and 1 (each within the scatter of the next).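

In this assay, placing hydroxy instead of amino on this aromatic carbon, next to the ring nitrogen and ortho to a fused ring, gives a number 0.03 log units higher from compound 2 to compound 4 (within the scatter), so the read-out does not tell these two compounds apart. Among the compounds shown here, this is the first view of the swap on its own, since the earlier compounds all differ from one another in more than one place and could not isolate any single change. On this core, at this position, an amino group and a hydroxy group are therefore interchangeable as far as this one read-out can show, and nothing available explains why the two groups give matching numbers.

Still open, as far as these compounds go, is how a larger or different group on the same carbon would read, such as methoxy, methylamino or a chlorine atom, since amino and hydroxy are each only a single heavy atom. Also open, from the compounds shown here alone, is whether the same swap would give a matching result on a different core, such as that of compound 1, so this single step cannot yet be taken as a general rule.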